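This account rests on a few compounds, and the source may have more. Where it says the series, first, only, none or still open, it means among the compounds named here.

Measured so far in a functional assay on HCT-116 cells (Homo sapiens) for inhibition, read by sulforhodamine B assay, with a stated time of 2 days; on this read-out lower numbers stand for stronger inhibition of growth and higher numbers for weaker inhibition of growth:

compound 1 `CC1=C(C(=O)Nc2cccc([N+](=O)[O-])c2)C(c2ccc(O)cc2O)NC(Nc2ccc([N+](=O)[O-])cc2Cl)=N1` gives 10900 nM
compound 2 `CC1=C(C(=O)Nc2cccc([N+](=O)[O-])c2)C(c2ccc(O)cc2O)NC(Nc2ccc(S(=O)(=O)Nc3ncccn3)cc2)=N1` gives 77600 nM
compound 3 `CC1=C(C(=O)Nc2cccc([N+](=O)[O-])c2)C(c2ccc(O)cc2O)NC(Nc2ccc(S(=O)(=O)Nc3nc(C)cc(C)n3)cc2)=N1` gives 8990 nM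

Compound 3 sits at the low end of these numbers in this assay, a place it shares with compound 1 within the scatter, and well under compound 2. The next compound, compound 4 `CC1=C(C(=O)Nc2cccc([N+](=O)[O-])c2)C(c2ccc(O)cc2O)NC(Nc2ccc(S(=O)(=O)Nc3cc(C)on3)cc2)=N1`, carries 5-methyl-1,2-oxazol-3-yl in place of 4,6-dimethylpyrimidin-2-yl on a sulfonamide nitrogen. Among the compounds with values here, only one measured step bears on this change, namely an 8.6-fold lower number from compound 2 to compound 3 (0.94 log units; beyond the scatter), and it shows that the group on that nitrogen can move the number beyond the scatter. That step kept the six-membered ring, whereas this one replaces it, so it gives only a loose guide to direction. A step smaller than that one is expected, leaning slightly towards a higher number and possibly within the scatter. The expected step is a 1.6-fold higher number from compound 3 to compound 4 (0.19 log units; within the scatter). For compound 4 the estimated value is 14000 nM, with an expected range from 4500 nM to 45000 nM.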

Compound 4, concentration for 50% growth inhibition: 16600 nM
Compound 4: middle estimate off by 1.2-fold (0.07 log units), on the low side; low and high end bracket the measured number.
By their numbers in this assay, from the lowest: compounds 3, 1 and 4 (each within the scatter of the next); then compound 2.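

In this assay the five-membered 5-methyl-1,2-oxazol-3-yl on the sulfonamide nitrogen stays within the scatter of the six-membered 4,6-dimethylpyrimidin-2-yl, with a 1.8-fold higher number from compound 3 to compound 4 (0.27 log units; within the scatter) so this position tolerates a change of ring size and hetero atoms without a step beyond the scatter. Set against pyrimidin-2-yl, the same group gives a 4.7-fold lower number from compound 2 to compound 4 (0.67 log units; beyond the scatter) so two different rings that each carry methyl now stand clear of compound 2 at this position. Nothing measured here accounts for these differences.

The compounds shown leave open whether the methyl groups alone set compound 3 and compound 4 apart from compound 2, and whether a plain phenyl ring or a carboxylic acid-bearing ring on the sulfonamide nitrogen would hold the number in the same range.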